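This account rests on a few compounds, and the source may have more. Where it says the series, first, only, none or still open, it means among the compounds named here.

The compounds here share one core. Compound 1 `CCCCCCCCCC(=O)Nc1ccc(O)c2ccccc12` carries a decanoyl group on a nitrogen on an aromatic ring, and in an assay on isolated protein for inhibition of histone acetyltransferase KAT2B (Homo sapiens), read by fluorescence, with a stated time of 5 min, in the presence of a further agent that is not named here (on this read-out higher numbers stand for weaker inhibition and lower numbers for stronger inhibition), compound 1 gives 160000 nM, a weak result. Compound 2 `CCC(=O)Nc1ccc(O)c2ccccc12` carries a propanoyl group in that place; in this assay compound 2 gives "not determined" (no result reported), so it stands nowhere on the numbers shown and serves only as the structural starting point. Compound 3 `CS(=O)(=O)Nc1ccc(O)c2ccccc12` differs from compound 2 by the change (methylsulfonyl in place of propanoyl on a nitrogen on an aromatic ring). Among the measured compounds shown here, no measured pair shows what such a swap does here, so the expectation for compound 3 in this assay rests only on the weak value of compound 1: a result of the same order, with no step in either direction that can be claimed beyond the scatter. Compound 3 is therefore expected to give about 150000 nM, most likely between 40000 nM and 500000 nM.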

Compound 3, half-maximal inhibitory concentration: 3800 nM
Compound 3: the middle estimate sits 39-fold (1.60 log units) above what was measured; the measured number lies below the stated range.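

Compound 2 has no number to set against compound 3, so no step can be read between them. The compounds shown leave open what swapping propanoyl for methylsulfonyl does on its own. Nothing measured here offers an explanation for the result of compound 3.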